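The source may hold more compounds than are shown below. What is called first, only, known or untested is meant among the compounds shown, and "the series" means these compounds.

The three measured compounds share one core and differ only in the aryl group attached to it. Compound 1 `CCCS(=O)(=O)Nc1ccc(F)c(C(=O)c2n[nH]c3ncc(-c4cccc(Cl)c4)cc23)c1F` carries a 3-chlorophenyl, and in an assay for binding affinity to dual specificity mitogen-activated protein kinase kinase 4 (Homo sapiens), read by KINOMEscan, tested at 100 nM (a lower number here means a stronger effect, a higher number a weaker effect of the compound at the concentration tested), compound 1 gives 40%. Compound 2 `CCCS(=O)(=O)Nc1ccc(F)c(C(=O)c2n[nH]c3ncc(-c4ccc(O)cc4)cc23)c1F` carries a 4-hydroxyphenyl, and in this assay compound 2 gives 0.75%, the lowest of the three numbers and therefore the strongest binder in the set. Compound 3 `CCCS(=O)(=O)Nc1ccc(F)c(C(=O)c2n[nH]c3ncc(-c4cccc(N(C)C)c4)cc23)c1F` carries a 3-(dimethylamino)phenyl, and in this assay compound 3 gives 26%. The measured steps are a number 39.3 percentage points lower from compound 1 to compound 2 (beyond the scatter) and a number 14 percentage points lower from compound 1 to compound 3 (beyond the scatter) and a number 25.3 percentage points higher from compound 2 to compound 3 (beyond the scatter), so compound 2 lies beyond the scatter below both of the others.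

Compound 4 `CCCS(=O)(=O)Nc1ccc(F)c(C(=O)c2n[nH]c3ncc(-c4ccc(S(=O)(=O)NC(C)=O)cc4)cc23)c1F` has not yet been measured. Against compound 2 it differs as follows: acetylsulfamoyl in place of hydroxy on an aromatic carbon. Among the measured compounds shown here, no measured step exchanges the hydroxy for a group of this kind. The two steps that bear on the question are a number 39.3 percentage points lower from compound 1 to compound 2 (beyond the scatter) and a number 25.3 percentage points higher from compound 2 to compound 3 (beyond the scatter), which show that every departure from the 4-hydroxyphenyl in this small set raised the number in this assay. A modest rise is therefore expected, a number 14.3 percentage points higher from compound 2 to compound 4 (beyond the scatter), although the entering group keeps one hydrogen-bond donor. Compound 4 is estimated at 15%, within a range from 2% to 50%.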

Compound 4, a percentage reported as activity, at one concentration (the size of the read-out at that concentration, not a potency): 0.35%
For compound 4 the middle estimate is 14.7 percentage points above the measured one; measured number below the stated range.
By their numbers in this assay, from the lowest: compounds 4 and 2 (each within the scatter of the next); then compound 3; then compound 1.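

Exchanging the hydroxy for acetylsulfamoyl, on an aromatic carbon para to a large group, brings in 7 heavy atoms where 1 left, yet in this assay it gives a number 0.4 percentage points lower from compound 2 to compound 4 (within the scatter), so this position accepts a much larger group with no change beyond the scatter. Among the compounds shown here, compound 4 therefore goes against the pattern of the earlier compounds, in which each departure from the 4-hydroxyphenyl raised the number, and it shows that the hydroxy itself is not required for a number as low as that of compound 2; the rise seen in a number 25.3 percentage points higher from compound 2 to compound 3 (beyond the scatter) remains tied to the 3-(dimethylamino)phenyl alone. Nothing measured here explains why the two groups read alike in this assay.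

The compounds shown leave open whether other groups at this position, such as a carboxylic acid, an amine or a longer chain on the sulfonamide nitrogen, would also leave the number unchanged. They also leave open whether acetylsulfamoyl would be accepted on another carbon of the ring, where the chloro and dimethylamino groups of compound 1 and compound 3 sit.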